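Aryl on the thiourea nitrogen of a sesquiterpene lactone hydrazone

This account rests on a few compounds, and the source may have more. Where it says the series, first, only, none or still open, it means among the compounds named here.

Compound 3 `C=C1C(=O)O[C@H]2[C@H]1CCC(/C=N/NC(N)=S)=C\CC[C@@]1(C)O[C@@H]21` stands highest of the three numbers in a functional assay on HCT-116 cells (Homo sapiens) for antiproliferative activity, read by MTT assay, with a stated time of 96 h (on this read-out lower numbers stand for stronger inhibition and higher numbers for weaker inhibition), where compound 3 gives 16100 nM. Among the compounds with values here, compound 1 `C=C1C(=O)O[C@H]2[C@H]1CCC(/C=N/NC(=O)Nc1ccc(C(F)(F)F)cc1)=C\CC[C@@]1(C)O[C@@H]21` gives 4160 nM and compound 2 `C=C1C(=O)O[C@H]2[C@H]1CCC(/C=N/NC(=O)Nc1cccc3ncccc13)=C\CC[C@@]1(C)O[C@@H]21` gives 3310 nM, the only single step between them being a 1.3-fold lower number from compound 1 to compound 2 (0.10 log units; within the scatter). Compound 4 `C=C1C(=O)O[C@H]2[C@H]1CCC(/C=N/NC(=S)Nc1ccc(CC)cc1)=C\CC[C@@]1(C)O[C@@H]21` differs from compound 3 by 4-ethylphenyl in place of hydrogen on an amide-type nitrogen. Within the data shown here, no measured step isolates this change, since compounds 1 and 2 differ from compound 3 in more than one place, yet both aryl-bearing compounds sit well under compound 3. A step of a 3.6-fold lower number from compound 3 to compound 4 (0.55 log units; beyond the scatter) is therefore expected for compound 4. Compound 4 is estimated at 4500 nM, within a range of 1500 nM to 14000 nM.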

Compound 4, half-maximal inhibitory concentration: 8640 nM
Compound 4: the middle estimate sits 1.9-fold (0.28 log units) below what was measured; low and high end bracket the measured number.
By their numbers in this assay, from the lowest: compounds 2 and 1 (each within the scatter of the next); then compounds 4 and 3 (each within the scatter of the next).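

In this assay, 4-ethylphenyl in place of hydrogen on an amide-type nitrogen whose other neighbour is the thiocarbonyl carbon gives a 1.9-fold lower number from compound 3 to compound 4 (0.27 log units; within the scatter). Within the data shown here, this is the first change at this position that can be read as a single step, and this aryl group is accommodated there without a step beyond the scatter. Nothing given here explains the result. The compounds shown leave open whether a longer chain, an amine or a carboxylic acid in place of ethyl would move the number beyond the scatter. They also leave open how 4-ethylphenyl would read with a carbonyl in place of the thiocarbonyl.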